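This account rests on a few compounds, and the source may have more. Where it says the series, first, only, none or still open, it means among the compounds named here.

Of the compounds shown here, two have been tested so far in a functional assay on HeLa cells (Homo sapiens) for antiproliferative activity, read by MTT assay, with a stated time of 72 h; on this read-out higher numbers stand for weaker inhibition and lower numbers for stronger inhibition. Compound 1 `COc1cccc(N2C(=O)COc3ccc(-c4cnc(Cl)c(NS(=O)(=O)c5ccc(F)cc5)c4)cc32)c1` gave only a limit, > 40000 nM, and not an exact number. Among the measured compounds shown here, compound 2 `COc1ncc(-c2ccc3c(c2)NC(=O)CO3)cc1NS(=O)(=O)c1ccc(F)cc1` gives 7110 nM, the only exact number available, which makes it the single firm reference point.

Compound 3 `COc1ncc(-c2ccc3c(c2)N(C2CCCCC2)C(=O)CO3)cc1NS(=O)(=O)c1ccc(F)cc1` keeps the structure of compound 2 except in one place, with cyclohexyl in place of hydrogen on an amide-type nitrogen in a ring. For the measured compounds named here, no measured step yet shows what a group on this nitrogen does in this assay, so any forecast must remain loose. A modest move towards weaker inhibition is expected, and the estimated step is a 2.1-fold higher number from compound 2 to compound 3 (0.32 log units; beyond the scatter). For compound 3 the estimated value is 15000 nM, with an expected range from 4000 nM to 40000 nM.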

Compound 3, half-maximal inhibitory concentration: 6100 nM
Estimate against measurement, compound 3: 2.5-fold (0.39 log units) above, within the range that was stated.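

Among the compounds shown here, this is the first measured step at this nitrogen, and in this assay it is a 1.2-fold lower number from compound 2 to compound 3 (0.07 log units; within the scatter). The amide hydrogen can therefore give way to cyclohexyl, a group of six carbon atoms, and the two compounds still cannot be told apart, so in this pair neither that hydrogen nor the added ring makes a measurable difference. Neither compound sits at the limit of the read-out, so this match is between two exact numbers and not two compounds stuck at the same ceiling: the limit of > 40000 nM in this assay, at which 1 of the 3 values shown sits.

Going by these compounds, whether a methyl group, a longer chain, or a group carrying an amine or a carboxylic acid on this nitrogen would also leave the number unmoved remains open. So does the question of whether cyclohexyl would behave the same way with a different group on the rest of the core.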